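This account rests on a few compounds, and the source may have more. Where it says the series, first, only, none or still open, it means among the compounds named here.

Three measured compounds share one core and differ only in the group on a six-membered aromatic ring of carbon only. Compound 1 `Cc1ccccc1C(=O)Nc1sc2c(c1C(N)=O)CCN(C(=S)Nc1ccccc1Cl)C2` carries chloro there; in a functional assay on HeLa cells (Homo sapiens) for antiproliferative activity, with a stated time of 24 h (a lower number here means a stronger inhibitor, a higher number a weaker inhibitor), compound 1 gives 35300 nM. Compound 2 `Cc1ccccc1C(=O)Nc1sc2c(c1C(N)=O)CCN(C(=S)Nc1ccccc1Br)C2` carries bromo; in this assay compound 2 reaches the limit > 50000 nM, a limit of the assay and not a number. Compound 3 `Cc1ccccc1C(=O)Nc1sc2c(c1C(N)=O)CCN(C(=S)Nc1ccccc1C(F)(F)F)C2` carries trifluoromethyl; in this assay compound 3 likewise sits at the limit > 50000 nM, again a limit and not a number. Compound 3 therefore stands at the limit of > 50000 nM in this assay, at which 2 of the 3 values shown sit, and the steps of an at least 1.4-fold higher number from compound 1 to compound 2 (0.15 log units; that floor lies within the scatter) and an at least 1.4-fold higher number from compound 1 to compound 3 (0.15 log units; that floor lies within the scatter) have floors within the scatter, while a step that the two limits leave unreadable from compound 2 to compound 3 cannot be read. Compound 4 `Cc1ccccc1NC(=S)N1CCc2c(sc(NC(=O)c3ccccc3C)c2C(N)=O)C1` differs from compound 3 by methyl in place of trifluoromethyl on an aromatic carbon. Going by the values given here, no measured step puts methyl at that position; the steps that touch the trifluoromethyl, an at least 1.4-fold higher number from compound 1 to compound 3 (0.15 log units; that floor lies within the scatter) and a step that the two limits leave unreadable from compound 2 to compound 3, show only that every measured compound is weak in this assay. For compound 4 the step of an at least 1.1-fold lower number from compound 3 to compound 4 (0.04 log units; that floor lies within the scatter) is expected to be none beyond the scatter. Compound 4 is estimated at 45000 nM, within a range of 20000 nM to 100000 nM, with a fair chance that only a limit is reported.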

Compound 4, half-maximal inhibitory concentration: > 50000 nM
Compound 4 gave a limit, no number; the forecaster's own chance of this, stated with the estimate: 50%; middle value at least 1.1-fold (0.04 log units) from the limit.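

In this assay compound 4 gives > 50000 nM, which is a limit of the assay and not a number. Methyl, ortho to a large group, is the first group shown at this position that carries no halogen, yet the one step that can be read, an at least 1.4-fold higher number from compound 1 to compound 4 (0.15 log units; that floor lies within the scatter), has a floor within the scatter, and the steps to compound 4 from compound 2 and compound 3 cannot be read. The change from 2-(trifluoromethyl)phenyl to 2-methylphenyl therefore adds one more compound at the same limit and gives no measurable separation from the other groups, so the series now reads: the limit of > 50000 nM in this assay, at which 3 of the 4 values shown sit.

The compounds shown leave open how far compound 2, compound 3 and compound 4 really lie from compound 1, and whether any of them differ from one another, since their values are limits. They also leave open whether a group of another kind at this position, such as an amine, a carboxylic acid or a longer chain, would give a readable number in this assay.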